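Adding a Second Chlorine to a Near-Inactive Rhodanine Pair

The source may hold more compounds than are shown below. What is called first, only, known or untested is meant among the compounds shown, and "the series" means these compounds.

Measured so far:
Compound 1 `O=C1NC(=S)/C(=C/c2ccc(Cl)cc2)S1` gives 0.92% in a functional assay on HEp-2 cells (Homo sapiens) for cytotoxicity, read by MTT assay, with a stated time of 72 h, tested at 1.25 ug/mL; a lower number here means less inhibition of growth, a higher number more inhibition of growth at the concentration tested.
Compound 2 `O=C1NC(=S)/C(=C/c2cccc(Cl)c2)S1` gives -0.36% in this assay.

Both numbers sit close to zero, and compound 2 stands within the scatter of compound 1, so neither compound inhibits growth to a measurable degree at this concentration. Compound 3 `O=C1NC(=S)/C(=C/c2ccc(Cl)c(Cl)c2)S1` carries one further change: chloro in place of hydrogen on an aromatic carbon. Within the data shown here, no step between measured compounds is available to guide the size of the effect. Since compound 2 and compound 1 both sit near zero, the expected step of a number 2.4 percentage points higher from compound 2 to compound 3 (within the scatter) in this assay is none beyond the scatter. Compound 3 is therefore estimated at 2%, within -8% to 14%.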

Compound 3, percent growth inhibition at one concentration: -5.45%
For compound 3 the middle estimate is 7.5 percentage points above the measured one; measured number inside the range.
By their numbers in this assay, from the lowest: compounds 3, 2 and 1 (each within the scatter of the next).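

In this assay, placing a chloro group on the aromatic carbon ortho to the existing chloro group gives a number 5.1 percentage points lower from compound 2 to compound 3 (within the scatter) and, counted from the other single-chlorine compound, a number 6.4 percentage points lower from compound 1 to compound 3 (within the scatter) as well. A second chlorine on this ring therefore brings no measurable growth inhibition at the concentration tested, a point that the two single-chlorine compounds could not show. No measurement shown here offers an explanation for this result.

Still open, as far as these compounds go, is whether an amine or a carboxylic acid on this same aromatic carbon would move the number beyond the scatter. Also open, from the compounds shown here alone, is whether any group here can produce real growth inhibition on the shared core.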